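Taking the chloro group off compound 2

The compounds below may be only part of what the source reports. "The series", "measured", "known", "first", "only" and "open" are said of these compounds alone.

- compound 1 `CCOc1ccc(F)cc1C(C)NC(=O)NS(=O)(=O)c1ccc(C)cc1`: > 300000 nM
- compound 2 `CCOc1ccc(F)cc1C(C)NC(=O)NS(=O)(=O)c1ccc(Cl)cc1`: > 300000 nM

In a functional assay on thoracic aorta (Rattus norvegicus, strain Wistar), with a stated time of 15 min (on this read-out higher numbers stand for an effect only at larger amounts of compound and lower numbers for an effect already at smaller amounts), compound 2 gives > 300000 nM, which is a limit of the assay and not a number. Compound 2 thus stands at the limit of > 300000 nM in this assay, at which 2 of the 2 values shown sit. Compound 3 `CCOc1ccc(F)cc1C(C)NC(=O)NS(=O)(=O)c1ccccc1` carries hydrogen in place of chloro on an aromatic carbon. Going by the values given here, the one measured step, a step that the two limits leave unreadable from compound 1 to compound 2, also swaps a group on an aromatic carbon, but it offers no size to carry over. In this assay the expected step is a number no higher from compound 2 to compound 3 (the limit leaves the size open), so no change beyond the scatter is expected. For compound 3 the estimate is 300000 nM, with an expected range of 120000 nM to 300000 nM.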

Compound 3, half-maximal effective concentration: > 300000 nM
Compound 3 ended at the assay's limit; the forecaster's own chance of this, stated with the estimate: 85%; the middle value sits exactly at the limit.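

Going by these compounds alone, compound 1, compound 2 and compound 3 all end at a limit and not at a number, so no step between them can be read: the limit of > 300000 nM in this assay, at which 3 of the 3 values shown sit. As far as these compounds go, whether methyl, chloro or hydrogen on that aromatic carbon makes any difference to the effect in this assay stays open.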